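The source may report more compounds than this note shows. Statements on the series, on what has been measured and on what is new or still open speak of the compounds shown alone.

Measured in an ADME assay on BJ cells (Homo sapiens) for cytotoxicity, with a stated time of 72 h; a lower number here means that less compound is needed, a higher number that more compound is needed for the effect:
- Compound 1 `C=C[C@@](C)(/C=C/c1ccc(O)cc1)CCC=O`: > 36600 nM
- Compound 2 `C=C[C@@](C)(/C=C/c1ccc(O)cc1)CC/C=C(C)/C=C/C(=O)OCc1ccccc1`: > 36600 nM
- Compound 3 `C=C[C@@](C)(/C=C/c1ccc(O)c(/C=C/C(=O)c2ccccc2)c1)CCC=C(C)C`: > 20000 nM

Each of these entries is a limit of the assay and not a number. Compound 3 stands at > 20000 nM, which is a limit. Among the compounds with values here, no compound in the set has yet given a number.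

Compound 4 `C=C[C@@](C)(/C=C/c1ccc(O)c(/C=C/c2ccc(Cl)cc2)c1)CCC=C(C)C` differs from compound 3 by one change, 4-chlorophenyl in place of benzoyl on a double-bonded chain carbon bound to a double-bonded chain carbon. Within the data shown here, no measured pair shows what such a change does, so the expectation is no step beyond the scatter. The expected step, a step that the limit leaves unreadable from compound 3 to compound 4, has no clear direction. The estimate for compound 4 is 25000 nM, with an expected range from 9000 nM to 45000 nM.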

Compound 4, half-maximal effective concentration: > 36600 nM
Compound 4: a limit, no number; the forecaster's own chance of this, stated with the estimate: 70%; middle value at least 1.4-fold (0.16 log units) away from the limit.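

Within the data shown here, compound 3 and compound 4 each stand only at a limit of the assay, and no step between them can be read. The compounds shown leave open whether 4-chlorophenyl in place of benzoyl changes the read-out at all.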